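This account rests on a few compounds, and the source may have more. Where it says the series, first, only, none or still open, it means among the compounds named here.

Two compounds of this series carry numbers in a physicochemical assay for solubility; on this read-out higher numbers stand for higher solubility and lower numbers for lower solubility. Compound 1 `CN(C)c1ccc(C[C@@H]2[C@H](O)[C@@H](O)[C@@H](Cc3ccc(N(C)C)cc3)N(Cc3cccc(C(=O)Nc4nc5ccccc5[nH]4)c3)C(=O)N2Cc2cccc(C(=O)Nc3nc4ccccc4[nH]3)c2)cc1` gives 13.2 ug/mL. Compound 2 `CC(C)C[C@@H]1[C@H](O)[C@@H](O)[C@@H](Cc2ccccc2)N(Cc2cccc(C(=O)Nc3nc4ccccc4[nH]3)c2)C(=O)N1Cc1cccc(C(=O)Nc2nc3ccccc3[nH]2)c1` gives 160 ug/mL, the highest of the two numbers; the nearest to it is compound 1, and the gap between the two values lies beyond the scatter. Among the compounds with values here, no step between measured compounds differing in a single place is on hand, so no measured step can be set beside the change now considered.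

Compound 3 `CCCCCC[C@@H]1[C@H](O)[C@@H](O)[C@@H](Cc2ccccc2)N(Cc2cccc(C(=O)Nc3nc4ccccc4[nH]3)c2)C(=O)N1Cc1cccc(C(=O)Nc2nc3ccccc3[nH]2)c1` is not yet measured. It differs from compound 2 in one place: pentyl in place of isopropyl on a saturated chain carbon bound to a saturated ring carbon. The change keeps the shared core of compound 2 and exchanges one saturated chain for a longer unbranched one, with no change in donors, acceptors or charge.

The step of a 3.2-fold lower number from compound 2 to compound 3 (0.51 log units; beyond the scatter) is expected to be a decrease of moderate size, beyond the scatter. Compound 3 is estimated at 50 ug/mL in this assay, with a range from 15 ug/mL to 130 ug/mL.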

Compound 3, solubility: 118 ug/mL
The estimate for compound 3 lay 2.4-fold (0.37 log units) below the measured number; the range from low to high includes it.
By their numbers in this assay, from the lowest: compound 1; then compounds 3 and 2 (each within the scatter of the next).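

In this assay, within the data shown here, the first step that differs in a single place is a 1.4-fold lower number from compound 2 to compound 3 (0.13 log units; within the scatter). On a saturated chain carbon bound to a saturated ring carbon, this read-out therefore does not separate the branched isopropyl of compound 2 from the longer unbranched pentyl of compound 3, so for this pair, chain length and branching at this place leave the number within the scatter. No measurement on hand bears on why the two chains read alike.

From the compounds shown here alone, whether a longer chain such as octyl, or a chain ending in an amine or a carboxylic acid, would read the same at this place in this assay remains open. This is also a single pair on one shared core, and it cannot show whether the same exchange would read alike with other groups elsewhere on that core.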